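This account rests on a few compounds, and the source may have more. Where it says the series, first, only, none or still open, it means among the compounds named here.

In a functional assay on ECa-109 cells for inhibition, with ECa-109 cell line (Homo sapiens) as the target, read by MTT assay, with a stated time of 48 h (a lower number here means a stronger inhibitor, a higher number a weaker inhibitor), compound 1 (`COc1ccc(-c2coc3cc(OCCCBr)ccc3c2=O)cc1`) gives 39700 nM and compound 3 (`COc1ccc(-c2coc3cc(OCCCSC(=S)N4CCCC4)ccc3c2=O)cc1`) gives 30800 nM while compound 2 (`COc1ccc(-c2coc3cc(OCCCSC(=S)N4CCN(Cc5ccccc5)CC4)ccc3c2=O)cc1`) gives 25300 nM and so stands within the scatter of both. The change to compound 4 (`COc1ccc(-c2coc3cc(OCCCSC(=S)N4CCN(C(=O)OC(C)(C)C)CC4)ccc3c2=O)cc1`) is tert-butoxycarbonyl in place of benzyl on an amine nitrogen in a ring starting from compound 2. Going by the values given here, the only measured step (a 1.3-fold lower number from compound 1 to compound 3 (0.11 log units; within the scatter)) lies within the scatter and replaces bromine, not the group on this nitrogen, so it bears only loosely. Among the compounds with values here, no measured step covers this exchange, and none beyond the scatter is expected in this assay for it. The estimated step (a 1.1-fold higher number from compound 2 to compound 4 (0.04 log units; within the scatter)) is expected to stay within the scatter. For compound 4 the estimated value is 28000 nM with an expected range from 14000 nM to 55000 nM in this series.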

Compound 4, half-maximal inhibitory concentration: 3540 nM
Estimate against measurement, compound 4: 7.9-fold (0.90 log units) above; measured number outside the range, below it.
By their numbers in this assay, from the lowest: compound 4; then compounds 2, 3 and 1 (each within the scatter of the next).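

In this assay, going by these compounds alone, the group on the amine nitrogen in a ring carries a step beyond the scatter: tert-butoxycarbonyl in place of benzyl gives a 7.1-fold lower number from compound 2 to compound 4 (0.85 log units; beyond the scatter), whereas the earlier compounds stayed within the scatter of each other. The entering group has no ring and 2 hydrogen-bond acceptors, while the leaving group has an aromatic ring and none. No evidence on the reason for this step is available.

The compounds shown leave open which part of tert-butoxycarbonyl goes with the step. An acetyl group or a free amine on this nitrogen would help separate the carbonyl from the tert-butyl part.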